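Compound 3: one more chain carbon than compound 2

The source may report more compounds than this note shows. Statements on the series, on what has been measured and on what is new or still open speak of the compounds shown alone.

Compound 1 `CCCCCC(CCO)n1cnc2c(N(C)C)ncnc21`: > 50000 nM (a limit)
Compound 2 `CCCCCCCCCC(CCO)n1cnc2c(N(C)C)ncnc21`: 9810 nM
Compound 3 `CCCCCCCCCCC(CCO)n1cnc2c(N(C)C)ncnc21`: not yet measured

All three compounds share one core and differ only in the length of their saturated chain. Antiproliferative strength was read in a functional assay on HCT-116 cells (Homo sapiens) for antiproliferative activity, read by MTT assay, with a stated time of 48 h; on this read-out higher numbers stand for weaker inhibition and lower numbers for stronger inhibition. Compound 1 gives > 50000 nM, which is a limit of the assay and not a number. Going by the values given here, compound 2, at 9810 nM, therefore holds the only true number so far.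

Compound 3 differs from compound 2 by methyl in place of hydrogen on a saturated chain carbon, ten or more bonds along the chain from an aromatic nitrogen. Among the compounds with values here, only one measured step bears on this change. Placing butyl on the chain gave an at least 5.0-fold lower number from compound 1 to compound 2 (0.70 log units; beyond the scatter), a step beyond the scatter, though its true size is unknown since it starts from a limit. Methyl is a smaller addition than butyl, so a smaller step in the same direction is expected, quite possibly within the scatter. The expected change is a 1.4-fold lower number from compound 2 to compound 3 (0.15 log units; within the scatter). For compound 3 the estimated value is 7000 nM, with an expected range of 3000 nM to 15000 nM.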

Compound 3, half-maximal inhibitory concentration: 5490 nM
For compound 3 the middle estimate is 1.3-fold (0.11 log units) above the measured one; low and high end bracket the measured number.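

In this assay, methyl in place of hydrogen at this far point of the chain gives a 1.8-fold lower number from compound 2 to compound 3 (0.25 log units; within the scatter), so this single added carbon does not clearly separate the two compounds, and a real difference cannot be claimed from these values. The wider comparison holds up with the longer chain: pentyl in place of hydrogen on the saturated chain carbon six bonds along from the aromatic nitrogen gives an at least 9.1-fold lower number from compound 1 to compound 3 (0.95 log units; beyond the scatter), so both compounds with the longer chains, compound 2 and compound 3, stand clear of compound 1 by more than the scatter. The true size of that wider step stays unknown, since compound 1 gives a limit and not a number: the limit of > 50000 nM in this assay, at which 1 of the 3 values shown sits.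

The compounds shown leave open whether a still longer chain would move the number beyond the scatter from compound 3, or whether the values would stay level from here on. They also leave open what an amine or a carboxylic acid would do in place of the added methyl on the same chain.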